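Dropping One Trifluoromethyl from Compound 3's Urea

This account rests on a few compounds, and the source may have more. Where it says the series, first, only, none or still open, it means among the compounds named here.

Going by the values given here, compound 3 `O=C(Nc1cccc(-n2cc(-c3ccncc3)c(-c3ccc(Cl)c(O)c3)n2)c1)Nc1cc(C(F)(F)F)cc(C(F)(F)F)c1` gives 746 nM in a functional assay on HT-29 cells (Homo sapiens) for inhibition, read by sulforhodamine B assay, with a stated time of 48 h (a higher number here means a weaker inhibitor of growth, a lower number a stronger inhibitor of growth), the lowest of the three numbers so far. Compound 2 `COc1cc(-c2nn(-c3cccc(NC(=O)c4cccc(C(F)(F)F)c4)c3)cc2-c2ccncc2)ccc1Cl` gives 1390 nM, which sits within the usual scatter of that result, while compound 1 `COc1cc(-c2nn(-c3cccc(NC(=O)c4ccc(Cl)c(C(F)(F)F)c4)c3)cc2-c2ccncc2)ccc1Cl` gives 3380 nM, clearly higher. Compound 4 `O=C(Nc1cccc(-n2cc(-c3ccncc3)c(-c3ccc(Cl)c(O)c3)n2)c1)Nc1cccc(C(F)(F)F)c1` is compound 3 with one change: hydrogen in place of trifluoromethyl on an aromatic carbon. Among the compounds with values here, only one measured step resembles this, the loss of a halogen on the amide-bearing ring, a 2.4-fold lower number from compound 1 to compound 2 (0.39 log units; beyond the scatter), though that concerned chloro on a different ring system. Removing a small aromatic substituent there helped modestly, so compound 4 is expected to land close to compound 3, perhaps slightly lower, a step of a 1.2-fold lower number from compound 3 to compound 4 (0.09 log units; within the scatter). Compound 4 is estimated at 600 nM, between 250 nM and 1500 nM.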

Compound 4, concentration for 50% growth inhibition: 9820 nM
Compound 4: middle estimate off by 16-fold (1.21 log units), on the low side, and the stated range ends below it.
By their numbers in this assay, from the lowest: compounds 3 and 2 (each within the scatter of the next); then compound 1; then compound 4.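

Removing the trifluoromethyl that sits meta to a trifluoromethyl group raises the number sharply in this assay (a 13-fold higher number from compound 3 to compound 4 (1.12 log units; beyond the scatter)), so this substituent matters a great deal on this ring. Going by these compounds alone, the only earlier step, swapping chloro for hydrogen on a different scaffold, went the other way (a 2.4-fold lower number from compound 1 to compound 2 (0.39 log units; beyond the scatter)), so removing one substituent does not predict removing another here. No measurement is available that explains the change. Going by these compounds, whether a nitrile or an amine in this place would keep the lower number stays open, as does how a ring with no trifluoromethyl at all would behave.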